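A Silyl Ether in Place of an Acetate

A few compounds are considered here, and "the series" means these few. Any claim that something is new, unique, unknown or untested is made for them only; others in the source may bear on it.

Of the compounds shown here, three from this series have been tested in an ADME assay on DU-145 cells (Homo sapiens) for cytotoxicity, read by MTT assay, with a stated time of 72 h; on this read-out higher numbers stand for weaker inhibition and lower numbers for stronger inhibition. Compound 1, `COC(=O)c1cc(C2=C(c3cc(OC)c(OC)c(OC)c3)C(=O)CC2O[SiH2]C(C)(C)C)ccc1OC`, gives > 100 ug/mL, which is a limit of the assay rather than a number. Compound 2, `COc1ccc(OC)c(C2=C(c3cc(OC)c(OC)c(OC)c3)C(=O)CC2O[SiH2]C(C)(C)C)c1`, gives 100 ug/mL. The step of a number no higher from compound 1 to compound 2 (the limit leaves the size open) therefore cannot be sized. Compound 3, `COc1cc(C2=C(c3cc(C)c(OC)c(C)c3)C(OC(C)=O)CC2=O)cc(OC)c1OC`, gives > 100 ug/mL, again a limit of the assay and not a number. Compound 3 thus stands at the weak end of what has been seen, together with compound 1, as the limit of > 100 ug/mL in this assay, at which 2 of the 3 values shown sit, shows.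

Compound 4, `COc1cc(C2=C(c3cc(C)c(OC)c(C)c3)C(O[SiH2]C(C)(C)C)CC2=O)cc(OC)c1OC`, differs from compound 3 by a group of 5 heavy atoms (4 carbon, 1 silicon; no ring) in place of a group of 3 heavy atoms (2 carbon, 1 oxygen; no ring), on an oxygen on a saturated carbon. The same silicon-bearing group already sits on compound 1 and compound 2, which give no sign of strong inhibition. Among the measured compounds shown here, no measured step compares an acetyl with this group at the same oxygen, so the only guide is that every compound shown sits at or near the limit. In this assay compound 4 is therefore expected to show a step of a number no higher from compound 3 to compound 4 (the limit leaves the size open), that is, no change beyond the scatter. Compound 4 is estimated at 100 ug/mL, with a range from 50 ug/mL to 200 ug/mL, and it may well return only a limit.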

Compound 4, half-maximal inhibitory concentration: > 100 ug/mL
Compound 4 gave a limit, no number; the forecaster's own chance of this, stated with the estimate: 70%; the middle value sits exactly at the limit.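

In this assay compound 4 gives > 100 ug/mL, which is a limit of the assay and not a number. Among the compounds shown here, with limits on both sides, the exchange of acetyl for the silicon-bearing group on this oxygen cannot be read, and neither can the step linking compound 1 and compound 4; the new information is only that this group, on an oxygen on a saturated carbon, also gives no readable number when the compound carries 4-methoxy-3,5-dimethylphenyl. With 4-methoxy-3,5-dimethylphenyl in place of 2,5-dimethoxyphenyl, the one step that has a direction is a number no lower from compound 2 to compound 4 (the limit leaves the size open), and the series now gathers at one end: the limit of > 100 ug/mL in this assay, at which 3 of the 4 values shown sit.

The compounds shown leave open how far compound 1, compound 3 and compound 4 lie past that limit, so these three cannot be ranked against each other. They also leave open whether a free hydroxyl or an amine at this same saturated carbon would bring a value that can be read as a number.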